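The source may report more compounds than this note shows. Statements on the series, on what has been measured and on what is new or still open speak of the compounds shown alone.

compound 1 `CCOC(=O)CC1C(C(=O)OCC)=C(N)Oc2ccc(-c3ccc(C(C)(C)C)cc3)cc21`: 35500 nM
compound 2 `CCOC(=O)CC1C(C(=O)OCC)=C(N)Oc2c(-c3ccccc3)cccc21`: 49800 nM
compound 3 `CCOC(=O)C1=C(N)Oc2ccc(-c3ccccc3)cc2C1CC(=O)N1CCOCC1`: > 100000 nM

All three compounds were tested in a functional assay on Jurkat cells (Homo sapiens) for cytotoxicity, with a stated time of 48 h; a lower number here means a stronger inhibitor, a higher number a weaker inhibitor. Compound 1 at 35500 nM and compound 2 at 49800 nM lie within the usual scatter of each other. Compound 3 gives > 100000 nM, which is a limit of this assay and not a number.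

The next compound, compound 4 `CCOC(=O)C1=C(N)Oc2ccc(-c3ccccc3)cc2C1CC(=O)N(CC)CC`, has not yet been measured. It keeps the core of compound 3 and carries diethylamino in place of morpholin-4-yl on a carbonyl carbon. The group that enters has no ring, while the one that leaves is a six-membered non-aromatic ring.

Within the data shown here, no measured pair of compounds shows what this swap does in this assay, so any forecast is rough. The expectation rests on compound 1 with 35500 nM and compound 2 with 49800 nM, which show that relatives of compound 3 can give real numbers. The expected change is modest and toward stronger inhibition: an at least 1.5-fold lower number from compound 3 to compound 4 (0.18 log units; that floor lies within the scatter). A result that is again only a limit would be no surprise. The estimate for compound 4 is 65000 nM, with an expected range of 25000 nM to 130000 nM.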

Compound 4, half-maximal inhibitory concentration: 49600 nM
For compound 4 the middle estimate is 1.3-fold (0.12 log units) above the measured one; the range from low to high includes it.
By their numbers in this assay, from the lowest: compounds 1, 4 and 2 (each within the scatter of the next). At a limit, above all of these: compound 3.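

In this assay, the exchange of morpholin-4-yl for diethylamino on a carbonyl carbon is the only change shown that can be read directly, and it reads as an at least 2.0-fold lower number from compound 3 to compound 4 (0.30 log units; that floor lies within the scatter). Compound 3 gives > 100000 nM, which is a limit of the assay and not a number. Compound 4 gives a real number at this position, but the printed floor of the step lies within the scatter, and the true size of the step cannot be fixed, because one end of it is only a limit: the limit of > 100000 nM in this assay, at which 1 of the 4 values shown sits.

The compounds shown leave open whether the difference lies in losing the ring or in losing its oxygen: piperidin-1-yl, which has the same ring size with carbon in place of that oxygen, would separate the two, and pyrrolidin-1-yl would test a smaller ring. Also open, from the compounds shown here alone, is how this position responds to something other than a tertiary amide, such as a free carboxylic acid in place of the amide or a longer chain on its nitrogen.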